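From Cyclopentenyl to Phenyl Ester at the Aryl Terminus

This account rests on a few compounds, and the source may have more. Where it says the series, first, only, none or still open, it means among the compounds named here.

The three measured compounds share one core and differ only in the group placed on an aromatic carbon para to a large group. Compound 1 `COC(=O)N1CCCCC1c1ccc(CNc2nccc(C)c2NC(=O)CC#N)cc1` carries a 1-(methoxycarbonyl)piperidin-2-yl there; in an assay on isolated protein for binding affinity to B1 bradykinin receptor (Homo sapiens) (a lower number here means a stronger inhibitor, a higher number a weaker inhibitor), compound 1 gives only a limit, > 5000 nM (the limit of > 5000 nM in this assay, at which 1 of the 3 values shown sits). Compound 2 `COC(=O)C1CCCCC1c1ccc(CNc2nccc(C)c2NC(=O)CC#N)cc1` carries a 2-(methoxycarbonyl)cyclohexyl, and in this assay compound 2 gives 2.2 nM. Compound 3 `COC(=O)C1=C(c2ccc(CNc3nccc(C)c3NC(=O)CC#N)cc2)CCC1` carries a 2-(methoxycarbonyl)cyclopent-1-en-1-yl; in this assay compound 3 gives 126 nM, the higher of the two numbers, with a 57-fold higher number from compound 2 to compound 3 (1.76 log units; beyond the scatter) and an at least 39-fold lower number from compound 1 to compound 3 (1.59 log units; beyond the scatter).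

Compound 4 `COC(=O)c1ccccc1-c1ccc(CNc2nccc(C)c2NC(=O)CC#N)cc1` differs from compound 3 in one place: 2-(methoxycarbonyl)phenyl in place of 2-(methoxycarbonyl)cyclopent-1-en-1-yl on an aromatic carbon. Going by the values given here, no measured step exchanges a non-aromatic carbon ring for an aromatic one, so the only guidance is that ring changes at this position have moved the number strongly, as in a 57-fold higher number from compound 2 to compound 3 (1.76 log units; beyond the scatter) and an at least 2200-fold lower number from compound 1 to compound 2 (3.35 log units; beyond the scatter). A step in this assay beyond the scatter is therefore expected, most likely downward but with wide uncertainty. Compound 4 is estimated at 30 nM, between 5 nM and 300 nM, which is expected to mean a 4.2-fold lower number from compound 3 to compound 4 (0.62 log units; beyond the scatter).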

Compound 4, inhibition constant: 11 nM
Estimate against measurement, compound 4: 2.7-fold (0.44 log units) above; measured number inside the range.
By their numbers in this assay, from the lowest: compound 2; then compound 4; then compound 3. At a limit, above all of these: compound 1.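

Placing 2-(methoxycarbonyl)phenyl on this aromatic carbon shows that an aromatic ring of carbon only can stand here, with an 11-fold lower number from compound 3 to compound 4 (1.06 log units; beyond the scatter) in this assay. It does not fully match the non-aromatic six-membered ring, as a 5.0-fold higher number from compound 2 to compound 4 (0.70 log units; beyond the scatter) is a modest step but still beyond the scatter. The comparison with the piperidine carbamate, an at least 450-fold lower number from compound 1 to compound 4 (2.65 log units; beyond the scatter), starts from a limit and not from a number: the limit of > 5000 nM in this assay, at which 1 of the 4 values shown sits.

The compounds shown leave open whether ring size or aromatic character drives the step from the five-membered non-aromatic ring to the six-membered aromatic ring, as both change together. They also leave open whether a carboxylic acid or a primary amide could replace the methyl ester on the phenyl ring, and how a fluorine on that ring would act.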